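The source may hold more compounds than are shown below. What is called first, only, known or untested is meant among the compounds shown, and "the series" means these compounds.

Measured so far:
- compound 1, `O=C(Oc1ccc(Br)cc1C(=O)Nc1ccc(C(F)(F)F)cc1)c1ccc(Br)cc1`: 4200 nM
- compound 2, `Cc1ccc(C(=O)Oc2ccc(Cl)cc2C(=O)Nc2ccc(C(F)(F)F)cc2)cc1`: 6900 nM

Both were tested in a functional assay on HepG2 cells (Homo sapiens), read by MTT assay, with a stated time of 72 h; a lower number here means a stronger inhibitor, a higher number a weaker inhibitor. The numbers of compound 1 and compound 2 lie within the usual scatter of each other, so neither can be called the stronger of the two. Compound 3, `O=C(Oc1ccc(Br)cc1C(=O)Nc1ccc(C(F)(F)F)cc1)c1ccc([N+](=O)[O-])cc1`, is not yet measured. It differs from compound 1 by nitro in place of bromo on an aromatic carbon. Among the measured compounds shown here, no measured pair shows this change, so the expected step in this assay is small, in no clear direction, and likely within the scatter: the expected step is a 1.1-fold lower number from compound 1 to compound 3 (0.04 log units; within the scatter). Compound 3 is thus expected to give about 3800 nM, with a likely range from 1300 nM to 11000 nM.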

Compound 3, half-maximal inhibitory concentration: 1250 nM
Beside the measured number, compound 3's estimate is 3.0-fold (0.48 log units) above it; measured number outside the range, below it.
By their numbers in this assay, from the lowest: compound 3; then compounds 1 and 2 (each within the scatter of the next).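

Among the compounds shown here, at the position para to a large group on the 4-bromophenyl ring, the earlier compounds offered no step to read. In this assay, nitro in place of bromo now gives a 3.4-fold lower number from compound 1 to compound 3 (0.53 log units; beyond the scatter), so this position does respond to a change of group. No measurement shown explains why the number moved.

On these data alone, whether this step is particular to nitro stays open, since an amine, a nitrile or a carboxylic acid on the same carbon would show how other groups behave there. One step also cannot say whether nitro would have a similar effect elsewhere on the shared core.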